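A few compounds are considered here, and "the series" means these few. Any claim that something is new, unique, unknown or untested is made for them only; others in the source may bear on it.

For the measured compounds named here, compound 2 `Cc1cc(OCc2nnc(SCc3cccc(F)c3)o2)cc2oc(=O)cc(C)c12` is the only compound of the pair to give a number in a functional assay on MCF7 cells (Homo sapiens) for antiproliferative activity, read by MTT assay, with a stated time of 24 h; on this read-out lower numbers stand for stronger inhibition and higher numbers for weaker inhibition; in this assay compound 2 gives 26000 nM. Compound 1 `CCSc1nnc(COc2cc(C)c3c(C)cc(=O)oc3c2)o1` stands at the limit of this assay, where compound 1 gives > 100000 nM, and the limit of > 100000 nM in this assay, at which 1 of the 2 values shown sits, shows that this is a limit and not a number. The step of an at least 3.8-fold lower number from compound 1 to compound 2 (0.58 log units; beyond the scatter) is the only measured one, and it concerns the chain carbon bound to the sulfur, not the sulfur itself. Compound 3 `Cc1cc(OCc2nnc(S(=O)(=O)Cc3ccccc3)o2)cc2oc(=O)cc(C)c12` differs from compound 2 by benzylsulfonyl in place of (3-fluorobenzyl)sulfanyl on an aromatic carbon. The measured step offers no direct guide to a change at the sulfur, so the expected step of a 1.5-fold higher number from compound 2 to compound 3 (0.19 log units; within the scatter) is placed within the scatter, with a slight lean toward a higher number. Compound 3 is therefore estimated at 40000 nM in this assay, with an expected range from 10000 nM to 100000 nM.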

Compound 3, half-maximal inhibitory concentration: 38600 nM
For compound 3 the middle estimate is 1.0-fold (0.02 log units) above the measured one; measured number inside the range.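

In this assay, for the compounds shown here, the aromatic carbon of the five-membered ring now carries a sulfonyl group for the first time, and a 1.5-fold higher number from compound 2 to compound 3 (0.17 log units; within the scatter) shows that benzylsulfonyl and (3-fluorobenzyl)sulfanyl cannot be told apart at this position. Benzylsulfonyl also stands apart from ethylsulfanyl, with an at least 2.5-fold lower number from compound 1 to compound 3 (0.41 log units; beyond the scatter), so both compounds with an aromatic ring on this chain lie beyond the scatter from compound 1. The value of compound 1 is a limit and not a number, which leaves the true size of that step unknown: the limit of > 100000 nM in this assay, at which 1 of the 3 values shown sits.

Going by these compounds, compound 3 differs from compound 2 both at the sulfur and in the fluorine, and what each change does alone stays open, a question that a benzylsulfanyl group at this position could answer. Also open, on these data alone, is how an amine or a longer chain here would read in this assay.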